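The source may report more compounds than this note shows. Statements on the series, on what has been measured and on what is new or still open speak of the compounds shown alone.

Measured so far:
compound 1, `Cc1cccc(C2=CCN(C(=O)[C@H]3NCC4(CC4)C[C@@H]3C(=O)NO)CC2)c1` — 25 nM
compound 2, `COC(=O)N1CC2(CC2)C[C@H](C(=O)NO)[C@H]1C(=O)N1CC=C(c2ccccc2)C1` — 26 nM

Compound 1 has the lowest of the two numbers in an assay on isolated protein for binding affinity to disintegrin and metalloproteinase domain-containing protein 10 (Homo sapiens) (on this read-out lower numbers stand for stronger inhibition and higher numbers for weaker inhibition), but its nearest neighbour is compound 2, whose value in this assay is within the scatter of it, so the two stand together and neither can be called the stronger binder. Compound 1 is therefore the anchor for the next step.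

Compound 3, `O=C(NO)[C@H]1CC2(CC2)CN[C@@H]1C(=O)N1CC=C(c2cc(Cl)cc(Cl)c2)CC1`, keeps the shared core of compound 1 and changes only the aryl group on the ring carbon: 3,5-dichlorophenyl in place of 3-methylphenyl on a double-bonded ring carbon

Going by the values given here, no measured pair shows what such a change does, so the size of the step can only be anticipated. Given that both measured compounds sit close together in this assay, a step of only modest size is expected, most likely within the scatter, with a slight lean toward a lower number.

Compound 3 is expected to give about 18 nM in this assay, with a plausible range from 6 nM to 60 nM. The estimated step of a 1.4-fold lower number from compound 1 to compound 3 (0.14 log units; within the scatter) is expected to stay close to the scatter.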

Compound 3, half-maximal inhibitory concentration: 99 nM
The estimate for compound 3 lay 5.5-fold (0.74 log units) below the measured number; measured number outside the range, above it.
By their numbers in this assay, from the lowest: compounds 1 and 2 (each within the scatter of the next); then compound 3.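

Going by these compounds alone, replacing 3-methylphenyl with 3,5-dichlorophenyl on the double-bonded ring carbon gives a 4.0-fold higher number from compound 1 to compound 3 (0.60 log units; beyond the scatter) in this assay and is the first step that can be read, showing that the aryl group at this place on the shared core affects the read-out. The size of the step is beyond the scatter, although the two groups have the same aromatic ring of carbon only, no hydrogen-bond donors or acceptors and no net charge, so those counts alone do not track the number here. No measurement available for the series bears on why this exchange raises the number.

As this is a single step, it leaves open whether the higher number follows the removal of the methyl group, the first chlorine or the second chlorine, and 3-chlorophenyl or 3-methyl-5-chlorophenyl on the same ring carbon would separate these. It also leaves open how far this place tolerates other groups, such as a methoxy group, a nitrile or a pyridine ring in place of the phenyl ring.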